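A few compounds are considered here, and "the series" means these few. Any claim that something is new, unique, unknown or untested is made for them only; others in the source may bear on it.

Measured in a functional assay on HL-60 cells (Homo sapiens) for antiproliferative activity, read by XTT assay, with a stated time of 72 h; a lower number here means a stronger inhibitor, a higher number a weaker inhibitor:
Compound 1 `COc1ncnc2c1c(-c1cccs1)cn2[C@@H]1O[C@H](CO)[C@@H](O)[C@H]1O` gives 80 nM.
Compound 2 `CSc1ncnc2c1c(-c1cccs1)cn2[C@@H]1O[C@H](CO)[C@@H](O)[C@H]1O` gives 1130 nM.
Compound 3 `C#Cc1cn([C@@H]2O[C@H](CO)[C@@H](O)[C@H]2O)c2ncnc(OC)c12` gives 190 nM.

Two changes connect these compounds. The first, (methylsulfanyl in place of methoxy on an aromatic carbon), gave a 14-fold higher number from compound 1 to compound 2 (1.15 log units; beyond the scatter). The second, (ethynyl in place of thiophen-2-yl on an aromatic carbon), gave a 2.4-fold higher number from compound 1 to compound 3 (0.38 log units; beyond the scatter); that is how the core of compound 1 and the core of compound 3 differ. Compound 4 `C#Cc1cn([C@@H]2O[C@H](CO)[C@@H](O)[C@H]2O)c2ncnc(SC)c12` has not yet been measured in this assay. Within the data shown here, it arises from compound 3 by methylsulfanyl in place of methoxy on an aromatic carbon, the same change as the one from compound 1 to compound 2, at a place described in the same words. Because a 14-fold higher number from compound 1 to compound 2 (1.15 log units; beyond the scatter) was large, compound 4 is expected to be a clearly weaker inhibitor than compound 3, at about 2400 nM, with a likely range from 900 nM to 7000 nM. The step from compound 3 to compound 4 is expected to be a 13-fold higher number from compound 3 to compound 4 (1.10 log units; beyond the scatter), set a little below the earlier step. Among the measured compounds shown here, only one prior example of this change is known, so the range is kept wide.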

Compound 4, half-maximal inhibitory concentration: 50 nM
Estimate against measurement, compound 4: 48-fold (1.68 log units) above, outside the stated range (below it).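

In this assay, methylsulfanyl in place of methoxy gave a 3.8-fold lower number from compound 3 to compound 4 (0.58 log units; beyond the scatter), so on this core the change runs in the opposite direction to the one seen on the core of compound 1: the same change on two cores in this assay, a 14-fold higher number (1.15 log units; beyond the scatter) from compound 1 to compound 2 and a 3.8-fold lower number (0.58 log units; beyond the scatter) from compound 3 to compound 4, 54-fold (1.73 log units) apart, beyond the scatter of two such steps. Ethynyl in place of thiophen-2-yl gave a 23-fold lower number from compound 2 to compound 4 (1.35 log units; beyond the scatter), so the outcome of this change also depends on the group at the other place: the same change on two cores in this assay, a 2.4-fold higher number (0.38 log units; beyond the scatter) from compound 1 to compound 3 and a 23-fold lower number (1.35 log units; beyond the scatter) from compound 2 to compound 4, 54-fold (1.73 log units) apart, beyond the scatter of two such steps. These four compounds show that the two changes do not act independently here, but they do not show why, or how either change would behave on any other core.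

As far as these compounds go, what remains open is whether an ethoxy group or an amine in place of methoxy would also depend on the partner group. From the compounds shown here alone, it is also open whether a longer alkyne chain would behave like ethynyl.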